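The compounds below may be only part of what the source reports. "The series", "measured", "known", "first", "only" and "open" are said of these compounds alone.

The measured compounds, with their half-maximal inhibitory concentrations in an ADME assay on L6 cells (Rattus norvegicus) for cytotoxicity; a higher number here means a weaker inhibitor, a lower number a stronger inhibitor:

compound 1, `COc1ccc(C2CC3(N4CCCC4)CC(O)C2C(c2ccc(OC)cc2)C3)cc1`, gives 17900 nM
compound 2, `COc1ccc(C2CC3(N4CCCCC4)CC(O)C2C(c2ccc(OC)cc2)C3)cc1`, gives 44600 nM
compound 3, `O/N=C1\CC2(N3CCCC3)CC(c3ccccc3)C1C(c1ccccc1)C2`, gives 13500 nM

Compound 1 and compound 2 share a core and differ in one place: piperidin-1-yl in place of pyrrolidin-1-yl on a saturated ring carbon. This change brought a 2.5-fold higher number from compound 1 to compound 2 (0.40 log units; beyond the scatter), a step beyond the usual scatter of such measurements, so compound 2 is the weaker inhibitor of the two.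

Compound 3 has a different core, with an oxime in place of the hydroxy group and phenyl groups in place of the 4-methoxyphenyl groups; the difference between the two cores is not broken down here. Its value lies within the scatter of that of compound 1, so no order between those two can be read from the data, while compound 2 stands beyond the scatter from compound 3.

Compound 4, `O/N=C1\CC2(N3CCCCC3)CC(c3ccccc3)C1C(c1ccccc1)C2`, has not yet been measured. It differs from compound 3 in one place: piperidin-1-yl in place of pyrrolidin-1-yl on a saturated ring carbon. This is the same kind of change as that from compound 1 to compound 2, but not the same: around the place in compound 1 the neighbouring ring atoms bear a 4-methoxyphenyl group and a hydroxy group, whereas in compound 3 the neighbouring ring atom bears a phenyl group, and the oxime replaces the hydroxy group.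

Because the same kind of change gave a 2.5-fold higher number from compound 1 to compound 2 (0.40 log units; beyond the scatter), compound 4 is expected to show a step of a 2.4-fold higher number from compound 3 to compound 4 (0.37 log units; beyond the scatter) in this assay. This rests on one step in one core only, so the expectation carries real uncertainty. The estimate for compound 4 is 32000 nM, with a likely range from 16000 nM to 64000 nM.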

Compound 4, half-maximal inhibitory concentration: 24200 nM
Compound 4: the middle estimate sits 1.3-fold (0.12 log units) above what was measured; the range from low to high includes it.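

On the core bearing the oxime and the phenyl groups, piperidin-1-yl in place of pyrrolidin-1-yl brought a 1.8-fold higher number from compound 3 to compound 4 (0.25 log units; within the scatter) in this assay, so on this core alone the two groups cannot be told apart. Set beside the earlier step, the same change does not give measurably different results on the two cores: the same change on two cores in this assay, a 2.5-fold higher number (0.40 log units; beyond the scatter) from compound 1 to compound 2 and a 1.8-fold higher number (0.25 log units; within the scatter) from compound 3 to compound 4, 1.4-fold (0.14 log units) apart, within the scatter of two such steps. This shows that the results on the core of compound 1 and the core of compound 3 are compatible with one shared step, but it does not show that the change has a real effect on the second core. Two pairs are too few to make a rule for the series.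

Among the compounds shown, only pyrrolidin-1-yl and piperidin-1-yl stand on this saturated ring carbon, so it remains open how another amine, such as morpholin-4-yl or the open-chain dimethylamino group, would behave there. The hydroxy group appears only with the 4-methoxyphenyl groups and the oxime only with the phenyl groups, so the compounds shown also leave the separate contribution of each of these differences between the cores unresolved.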